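The compounds below may be only part of what the source reports. "The series", "measured", "known", "first", "only" and "open" are said of these compounds alone.

In a functional assay on HL-60 cells (Homo sapiens) for cytotoxicity, read by luminescence and CellTiter-Glo, with a stated time of 3 days (a higher number here means a weaker inhibitor, a lower number a stronger inhibitor), compound 1 `N#Cc1ccc(NC(=O)c2cc(Cl)ccc2O)cc1` gives 700 nM and compound 2 `N#Cc1ccc(NC(=O)c2cc(C(F)(F)F)ccc2O)cc1` gives 3120 nM, so compound 2 stands at the higher of the two numbers. Compound 3 `Cc1ccc(O)c(C(=O)Nc2ccc(C#N)cc2)c1` differs from compound 2 by one change: methyl in place of trifluoromethyl on an aromatic carbon. Among the measured compounds shown here, the one measured step that bears on this is a 4.5-fold higher number from compound 1 to compound 2 (0.65 log units; beyond the scatter), where trifluoromethyl entered in place of chloro. With trifluoromethyl now leaving, a modest fall no larger than that step is expected in this assay. The estimated change is a 2.1-fold lower number from compound 2 to compound 3 (0.32 log units; beyond the scatter). For compound 3 the estimate is 1500 nM, with an expected range of 500 nM to 4000 nM.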

Compound 3, half-maximal inhibitory concentration: 3920 nM
Compound 3: middle estimate off by 2.6-fold (0.42 log units), on the low side, and the stated range covers the measured number.
By their numbers in this assay, from the lowest: compound 1; then compounds 2 and 3 (each within the scatter of the next).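

In this assay, methyl in place of trifluoromethyl on this aromatic carbon, para to a hydroxy group, gives a 1.3-fold higher number from compound 2 to compound 3 (0.10 log units; within the scatter) and so leaves the two groups indistinguishable here. Chloro alone now stands apart: methyl in place of chloro gives a 5.6-fold higher number from compound 1 to compound 3 (0.75 log units; beyond the scatter) in the same direction as the earlier trifluoromethyl step. Nothing measured here explains why chloro differs from these two groups. The compounds shown leave open how a bromo group, a methoxy group or an amine would read at this position. They also leave open whether any group other than chloro matches compound 1.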